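Replacing Cyclohexyl with 4-Methoxyphenyl at the Ring Nitrogen

The compounds below may be only part of what the source reports. "The series", "measured", "known", "first", "only" and "open" are said of these compounds alone.

Compound 1 `COc1ncc(-c2ccc3c(c2)N(c2ccc(C)cc2)C(=O)CO3)cc1NS(=O)(=O)c1ccc(F)cc1`: 28300 nM
Compound 2 `COc1cccc(N2C(=O)COc3ccc(-c4cnc(Cl)c(NS(=O)(=O)c5ccc(F)cc5)c4)cc32)c1`: > 40000 nM (a limit)
Compound 3 `O=C1COc2ccc(-c3cnc(Cl)c(NS(=O)(=O)c4ccc(F)cc4)c3)cc2N1C1CCCCC1`: > 40000 nM (a limit)

In a functional assay on HepG2 cells (Homo sapiens) for antiproliferative activity, read by MTT assay, with a stated time of 72 h (on this read-out lower numbers stand for stronger inhibition and higher numbers for weaker inhibition), compound 3 has no exact number, only the limit > 40000 nM. Compound 2 also gives only a limit, > 40000 nM. This is the limit of > 40000 nM in this assay, at which 2 of the 3 values shown sit. Among the compounds with values here, compound 1 is the only one with a true number, 28300 nM.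

Compound 4 `COc1ccc(N2C(=O)COc3ccc(-c4cnc(Cl)c(NS(=O)(=O)c5ccc(F)cc5)c4)cc32)cc1` has not yet been measured. It differs from compound 3 by one change, 4-methoxyphenyl in place of cyclohexyl on an amide-type nitrogen in a ring.

Within the data shown here, only one measured step touches this place, a step that the two limits leave unreadable from compound 2 to compound 3. It links compound 3 with compound 2, which carries 3-methoxyphenyl there, but it has no readable size. No clear step is therefore expected in this assay, and no direction can be relied on, so a further limit is quite likely. The expected change is an at least 1.0-fold lower number from compound 3 to compound 4 (0.02 log units; that floor lies within the scatter). Compound 4 is estimated at 38000 nM, with an expected range from 18000 nM to 60000 nM.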

Compound 4, half-maximal inhibitory concentration: > 40000 nM
Compound 4: no number, only a limit; the forecaster's own chance of this, stated with the estimate: 60%; middle value at least 1.0-fold (0.02 log units) away from the limit.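

In this assay compound 4 gives only a limit, > 40000 nM, and not a number. Compound 2 and compound 3 also give only limits, so no step among these three compounds can be read: the limit of > 40000 nM in this assay, at which 3 of the 4 values shown sit.

The compounds shown leave open whether cyclohexyl, 3-methoxyphenyl and 4-methoxyphenyl on the amide-type nitrogen differ at all.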